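The source may report more compounds than this note shows. Statements on the series, on what has been measured and on what is new or still open speak of the compounds shown alone.

Compound 1 `COc1cc(-c2nn(-c3cccc(NC(=O)c4cccc(C(F)(F)F)c4)c3)cc2-c2ccncc2)ccc1Cl` gives 1320 nM in a functional assay on MDA-MB-468 cells (Homo sapiens) for inhibition, read by sulforhodamine B assay, with a stated time of 48 h (a higher number here means a weaker inhibitor, a lower number a stronger inhibitor), and stands as the higher of the two numbers in hand; compound 2 `O=C(Nc1cccc(-n2cc(-c3ccncc3)c(-c3ccc(Cl)c(O)c3)n2)c1)Nc1cc(C(F)(F)F)cc(C(F)(F)F)c1` gives 270 nM in this assay, a gap beyond the scatter. Compound 3 `COc1cc(-c2nn(-c3cccc(NC(=O)c4ccccc4)c3)cc2-c2ccncc2)ccc1Cl` differs from compound 1 by hydrogen in place of trifluoromethyl on an aromatic carbon. For the measured compounds named here, no measured pair shows this change, so its size is open. A modest rise in number is expected, a 1.9-fold higher number from compound 1 to compound 3 (0.28 log units; within the scatter), one that may still fall within the scatter. Compound 3 is therefore estimated at 2500 nM, between 800 nM and 8000 nM.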

Compound 3, half-maximal inhibitory concentration: 350 nM
For compound 3 the middle estimate is 7.1-fold (0.85 log units) above the measured one, outside the stated range (below it).
By their numbers in this assay, from the lowest: compounds 2 and 3 (each within the scatter of the next); then compound 1.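

For the compounds shown here, replacing trifluoromethyl with hydrogen on the benzoyl ring gives, in this assay, a 3.8-fold lower number from compound 1 to compound 3 (0.58 log units; beyond the scatter) as the first single-place step. Trifluoromethyl at this position is therefore not required for a low number on this core, and the plain phenyl gives the stronger inhibitor of this pair. No evidence in hand accounts for the size of this step.

Still open, going by these compounds, is whether fluorine, chlorine or an amine at this position would go with a higher or lower number than hydrogen. On these data alone, the same change also remains untested with the urea linker of compound 2.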